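The source may report more compounds than this note shows. Statements on the series, on what has been measured and on what is new or still open speak of the compounds shown alone.

Two compounds have been measured so far in a functional assay on HeLa cells (Homo sapiens) for inhibition, read by MTT assay, with a stated time of 48 h (on this read-out higher numbers stand for weaker inhibition of growth and lower numbers for stronger inhibition of growth), and give these values:

- compound 1 `COc1ccc2c(c1)c(C1CC(c3ccc(F)cc3)=NN1C(=O)c1ccc(OC)nc1)cn2C` gives 410 nM
- compound 2 `COc1ccc2c(c1)c(C1CC(c3ccc(Cl)cc3)=NN1C(=O)c1ccc(OC)nc1)cn2C` gives 2260 nM

Compound 2 has the higher number of the pair, which makes it the weaker growth inhibitor. Compound 3 `COc1ccc(C2=NN(C(=O)c3ccc(OC)nc3)C(c3cn(C)c4ccc(OC)cc34)C2)cc1` keeps the shared core and changes one group: methoxy in place of chloro on an aromatic carbon, para to a large group. Going by the values given here, only one measured step bears on this place: a 5.5-fold higher number from compound 1 to compound 2 (0.74 log units; beyond the scatter), a modest swap beyond the scatter. It shows that changing this group can move the number, but no methoxy value exists to fix the direction. A modest step towards a lower number, staying inside the span of the two known values, is a tentative expectation. The expected size is a 2.3-fold lower number from compound 2 to compound 3 (0.35 log units; beyond the scatter) as an estimate. The expected value for compound 3 is 1000 nM within an estimated range of 250 nM to 4000 nM overall.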

Compound 3, concentration for 50% growth inhibition: 180 nM
Estimate against measurement, compound 3: 5.6-fold (0.74 log units) above; the whole stated range lies above it.
By their numbers in this assay, from the lowest: compound 3; then compound 1; then compound 2.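

In this assay the swap of chloro for methoxy gives a 13-fold lower number from compound 2 to compound 3 (1.10 log units; beyond the scatter) and so shows that this position on the aromatic ring can move the number in the favourable direction, and by a large step. Methoxy also beats the better of the two halogens, with a 2.3-fold lower number from compound 1 to compound 3 (0.36 log units; beyond the scatter) and both steps beyond the scatter, which makes compound 3 the strongest growth inhibitor of the three and shows that the halogens did not mark the best this position can do. No measurement shown here explains why methoxy gives the lowest number.

Only fluoro, chloro and methoxy can be compared at this position. On these data alone, whether an ethoxy group, a hydroxyl or an amine there would lower the number further, or raise it again, remains open.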